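Taking one methyl away from compound 2

A few compounds are considered here, and "the series" means these few. Any claim that something is new, unique, unknown or untested is made for them only; others in the source may bear on it.

In a functional assay on MCF7 cells (Homo sapiens) for antiproliferative activity, read by sulforhodamine B assay, with a stated time of 48 h (a lower number here means a stronger inhibitor, a higher number a weaker inhibitor), compound 1 (`CCc1ccccc1NS(=O)(=O)c1ccc(N2CCNC2=O)cc1`) gives 350 nM while compound 2 (`Cc1cccc(NS(=O)(=O)c2ccc(N3CCNC3=O)cc2)c1`) gives 190 nM and compound 3 (`Cc1ccc(NS(=O)(=O)c2ccc(N3CCNC3=O)cc2)cc1C`) gives 230 nM in the same test. Compound 2 thus stands level with the other two, and all three values lie within the scatter of one another. Compound 4 (`O=C1NCCN1c1ccc(S(=O)(=O)Nc2ccccc2)cc1`) differs from compound 2 by hydrogen in place of methyl on an aromatic carbon and is a case of hydrogen in place of methyl on an aromatic carbon. The nearest measured evidence is a 1.2-fold higher number from compound 2 to compound 3 (0.08 log units; within the scatter) for the opposite kind of change, methyl in place of hydrogen, made at another carbon of the ring. Exchanging the whole ring substituent has also moved little, as a 1.8-fold lower number from compound 1 to compound 2 (0.27 log units; within the scatter) and a 1.5-fold lower number from compound 1 to compound 3 (0.18 log units; within the scatter) show. Going by the values given here, no measured compound carries a plain phenyl, so this reading is indirect. No step beyond the scatter is therefore expected in this assay for this change. The estimated step is a 1.3-fold higher number from compound 2 to compound 4 (0.12 log units; within the scatter) and it is expected to stay small. For compound 4 the estimate is 250 nM with an expected range of 110 nM to 600 nM in this test.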

Compound 4, half-maximal inhibitory concentration: 470 nM
Estimate against measurement, compound 4: 1.9-fold (0.27 log units) below, and the stated range covers the measured number.
By their numbers in this assay, from the lowest: compounds 2, 3, 1 and 4 (each within the scatter of the next, the first and the last beyond it).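

Losing the methyl from the 3-methylphenyl group gives the first step in this series to go beyond the scatter, a 2.5-fold higher number from compound 2 to compound 4 (0.39 log units; beyond the scatter), so this carbon, meta to a large group, is not as indifferent to change as the earlier compounds suggested. The phenyl of compound 4 also separates from the 3,4-dimethylphenyl group, with a 2.0-fold higher number from compound 3 to compound 4 (0.31 log units; beyond the scatter), yet the comparison with the 2-ethylphenyl group gives a 1.3-fold higher number from compound 1 to compound 4 (0.13 log units; within the scatter) and stays within the scatter, so compound 1 goes against any rule that every alkyl-bearing ring outdoes plain phenyl. As far as these compounds go, what an ethyl, a methoxy group or an amine would do at this same carbon remains open. So does the effect of a single methyl on the other carbons of the ring. Nothing available bears on what lies behind these steps.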